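The source may hold more compounds than are shown below. What is called first, only, known or untested is meant among the compounds shown, and "the series" means these compounds.

Values in a functional assay on A549 cells (Homo sapiens) for inhibition, read by sulforhodamine B assay, with a stated time of 72 h; a lower number here means a stronger inhibitor, a higher number a weaker inhibitor:

- compound 1 `COc1ccc(CN(Cc2ccccc2)Cc2c(O)ccc3c(=O)cc(C)oc23)cc1`: 14.1 ug/mL
- compound 2 `CCN(Cc1ccc(OC)cc1)Cc1c(O)ccc2c(=O)cc(C)oc12`: 38.7 ug/mL
- compound 3 `COc1ccc(CN(Cc2ccc3ccccc3c2)Cc2c(O)ccc3c(=O)cc(C)oc23)cc1`: 6.01 ug/mL
- compound 4 `COc1ccc(CN(Cc2ccc(OC)cc2)Cc2c(O)ccc3c(=O)cc(C)oc23)cc1`: not yet measured

Compound 3 gives the lowest of the three numbers, at 6.01 ug/mL. The next step under review is 4-methoxyphenyl in place of naphthalen-2-yl on a saturated chain carbon bound to an amine nitrogen.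

Three measured steps change this same place. They are a 2.7-fold higher number from compound 1 to compound 2 (0.44 log units; beyond the scatter), a 2.3-fold lower number from compound 1 to compound 3 (0.37 log units; beyond the scatter) and a 6.4-fold lower number from compound 2 to compound 3 (0.81 log units; beyond the scatter). Across them the number falls in the order methyl, phenyl, naphthalen-2-yl, and none of the three compounds goes against that order. Among the compounds with values here, the closest precedent is the step with phenyl and naphthalen-2-yl, a 2.3-fold lower number from compound 1 to compound 3 (0.37 log units; beyond the scatter), read in reverse, since compound 4 also gives up the naphthalen-2-yl for a single ring. Within the data shown here, no measured pair shows what the methoxy adds at this place, so that part of the change remains open.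

A modest rise in this assay is therefore expected, of about the size of that reversed step. The expected change is a 2.2-fold higher number from compound 3 to compound 4 (0.34 log units; beyond the scatter). For compound 4 the estimated value is 13 ug/mL, with an expected range of 6.5 ug/mL to 28 ug/mL.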

Compound 4, half-maximal inhibitory concentration: 62.5 ug/mL
Compound 4: middle estimate off by 4.8-fold (0.68 log units), on the low side; measured number outside the range, above it.
By their numbers in this assay, from the lowest: compound 3; then compound 1; then compounds 2 and 4 (each within the scatter of the next).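

Methoxy in place of hydrogen on an aromatic carbon now has its own measured pair in this assay, and it moves the number the wrong way: a 4.4-fold higher number from compound 1 to compound 4 (0.65 log units; beyond the scatter), so the added group is not neutral at this position, and the step from the two-ring group to the substituted single ring, a 10-fold higher number from compound 3 to compound 4 (1.02 log units; beyond the scatter), is much larger than the step to plain phenyl alone suggested. The earlier falling order of methyl, phenyl, naphthalen-2-yl therefore does not extend to every aromatic group: compound 4 goes against it, since a 1.6-fold higher number from compound 2 to compound 4 (0.21 log units; within the scatter) leaves this aromatic group no separable from the small alkyl end of the series, and an aromatic ring at this place does not by itself lower the number.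

As far as these compounds go, whether this loss belongs to methoxy in particular or to any substituent on that aromatic carbon remains open, and a chlorine or a hydroxyl in place of the methoxy on the same carbon would separate these readings. A methoxy on the naphthalen-2-yl group, or a longer chain such as butyl in place of the methyl, would also test how far the order holds.

Nothing on hand explains the size of the methoxy step.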